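Replacing cyano with an ester on the shared core

A few compounds are considered here, and "the series" means these few. Any claim that something is new, unique, unknown or untested is made for them only; others in the source may bear on it.

In a functional assay on DLD-1 cells (Homo sapiens) for cytotoxicity, with a stated time of 48 h (a lower number here means a stronger inhibitor, a higher number a weaker inhibitor), compound 3 `C[S+]([O-])/C=C/c1cc(=O)c2cc(C#N)ccc2o1` gives only a limit, > 10000 nM. Compound 1 `CC(=O)Oc1ccc2oc(/C=C/[S+](C)[O-])cc(=O)c2c1` also gives only a limit, > 10000 nM. For the measured compounds named here, compound 2 `CCCCC(=O)Oc1ccc2oc(/C=C/[S+](C)[O-])cc(=O)c2c1` gives the only number so far, 6700 nM.

Compound 4 `C[S+]([O-])/C=C/c1cc(=O)c2cc(OC(=O)C(C)(C)C)ccc2o1` carries ((tert-butyl)carbonyl)oxy in place of cyano on an aromatic carbon.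

The closest guide is the reverse kind of change, cyano replacing (butylcarbonyl)oxy, which gives an at least 1.4-fold higher number from compound 2 to compound 3 (0.17 log units; that floor lies within the scatter). Between the two esters, the record shows an at least 1.4-fold lower number from compound 1 to compound 2 (0.17 log units; that floor lies within the scatter). The remaining step, a step that the two limits leave unreadable from compound 1 to compound 3, adds no size. On these data alone, these steps set floors only, so the true sizes remain open.

A small move towards a lower number in this assay is expected, and a step too small to read is possible. The expected step is an at least 1.2-fold lower number from compound 3 to compound 4 (0.09 log units; that floor lies within the scatter). The estimate for compound 4 is 8000 nM. The estimated range for compound 4 runs from 3500 nM to 16000 nM.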

Compound 4, half-maximal inhibitory concentration: 8000 nM
Compound 4: the middle estimate sits on the measured number at the digits printed; low and high end bracket the measured number.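

In this assay, ((tert-butyl)carbonyl)oxy in place of cyano on an aromatic carbon gives a readable number where cyano gave only a limit, an at least 1.2-fold lower number from compound 3 to compound 4 (0.09 log units; that floor lies within the scatter), and replacing the methyl of the acetoxy ester with tert-butyl gives an at least 1.2-fold lower number from compound 1 to compound 4 (0.09 log units; that floor lies within the scatter); both floors lie within the scatter. Tert-butyl in place of butyl on the carbonyl carbon gives a 1.2-fold higher number from compound 2 to compound 4 (0.08 log units; within the scatter), so the two chains cannot be told apart in this assay. At this position, readable numbers come only from compound 2 and compound 4, while compound 1 and compound 3 remain limits: the limit of > 10000 nM in this assay, at which 2 of the 4 values shown sit.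

The step between those two limits cannot be read, and the floors leave the true sizes open. On these data alone, whether an amine, a carboxylic acid or an ester with a longer chain at this aromatic carbon would move the number beyond the scatter remains open.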